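The source may report more compounds than this note shows. Statements on the series, on what has been measured and on what is new or still open speak of the compounds shown alone.

Three analogues built on one shared core have been measured in a functional assay on SW-620 cells (Homo sapiens) for antiproliferative activity, read by MTT assay, with a stated time of 72 h, in the presence of a further agent that is not named here; on this read-out lower numbers stand for stronger inhibition and higher numbers for weaker inhibition. Compound 3 `Nc1nc2[nH]c(CCSCCC(=O)NCc3cccnc3)cc2c(=O)[nH]1` carries a pyridin-3-yl on a saturated chain carbon bound to an amide-type nitrogen, and in this assay compound 3 gives 665 nM, the lowest of the three numbers. Compound 1 `Nc1nc2[nH]c(CCSCCC(=O)NCc3ccccn3)cc2c(=O)[nH]1` differs from compound 3 by pyridin-2-yl in place of pyridin-3-yl on a saturated chain carbon bound to an amide-type nitrogen, and this single change produces an 18-fold higher number from compound 3 to compound 1 (1.25 log units; beyond the scatter), so that compound 1 gives 11900 nM in this assay. Compound 2 `Nc1nc2[nH]c(CCSCC(=O)NCc3cccnc3)cc2c(=O)[nH]1` differs from compound 3 in the core in a way that is not broken down here; in this assay compound 2 gives 25300 nM, the highest of the three numbers, and its gap to compound 3 is much wider than its gap to compound 1.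

Compound 4 `Nc1nc2[nH]c(CCSCC(=O)NCc3ccccn3)cc2c(=O)[nH]1` has not yet been measured. Going by the values given here, it differs from compound 2 by pyridin-2-yl in place of pyridin-3-yl on a saturated chain carbon bound to an amide-type nitrogen, which is the same change, at the same place, as the one from compound 3 to compound 1. Among the compounds with values here, with only that one precedent, compound 4 is expected to follow compound 2 in the same direction, with an estimated step of a 5.9-fold higher number from compound 2 to compound 4 (0.77 log units; beyond the scatter), because the earlier instance gave an 18-fold higher number from compound 3 to compound 1 (1.25 log units; beyond the scatter). Since compound 2 already starts from the highest number, the expectation for compound 4 in this assay is a value of about 150000 nM, with a plausible range from 40000 nM to 600000 nM, and a real chance that the assay reports only a limit rather than a number.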

Compound 4, half-maximal inhibitory concentration: 36100 nM
Estimate against measurement, compound 4: 4.2-fold (0.62 log units) above, and the stated range ends above it.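

In this assay, placing pyridin-2-yl in place of pyridin-3-yl on a saturated chain carbon bound to an amide-type nitrogen gives a 1.4-fold higher number from compound 2 to compound 4 (0.15 log units; within the scatter), so on the core of compound 2 this change has no effect that can be told from the scatter. The same change on the core of compound 3 gave an 18-fold higher number from compound 3 to compound 1 (1.25 log units; beyond the scatter), so its size did not carry over from one core to the other, and the gap between the two steps is a real one: the same change on two cores in this assay, an 18-fold higher number (1.25 log units; beyond the scatter) from compound 3 to compound 1 and a 1.4-fold higher number (0.15 log units; within the scatter) from compound 2 to compound 4, 13-fold (1.10 log units) apart, beyond the scatter of two such steps This shows that, among these four compounds, what the change does depends on the core that carries it, but two cores give no rule for any further core, and the numbers do not show why the two steps part.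

The compounds shown leave open how a phenyl or a pyridin-4-yl group would read in the same place on either core, and so whether the advantage of pyridin-3-yl on the core of compound 3 belongs to that group alone. They also leave open whether a longer chain would keep that advantage, lose it or widen it, and whether a carboxylic acid in place of the amide would leave any of these steps intact.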